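Swapping Methylsulfanyl for Methoxy in Compound 3

The source may hold more compounds than are shown below. What is called first, only, known or untested is meant among the compounds shown, and "the series" means these compounds.

Compound 1 `COc1cc(-c2ocnc2-c2cc(Br)c(OC)c(OC)c2)ccc1SC` gives 1030 nM
Compound 2 `COc1cc(-c2ncoc2-c2ccccc2SC)cc(OC)c1OC` gives > 20000 nM as a limit
Compound 3 `COc1ccc(-c2ocnc2-c2cc(Br)c(OC)c(OC)c2)cc1SC` gives 1160 nM

In a functional assay on SK-OV-3 cells (Homo sapiens) for cytotoxicity, read by MTT assay, with a stated time of 48 h (on this read-out lower numbers stand for stronger inhibition and higher numbers for weaker inhibition), compound 3 (1160 nM) lies within the scatter of compound 1 (1030 nM). Compound 2 gives only a limit (> 20000 nM). Compound 4 `COc1ccc(-c2ocnc2-c2cc(Br)c(OC)c(OC)c2)cc1OC` has methoxy in place of methylsulfanyl on an aromatic carbon, ortho to a methoxy group (methoxy in place of methylsulfanyl on an aromatic carbon). Among the compounds with values here, no measured pair shows this swap, so the expectation rests on compound 3 (1160 nM) and stays broad. A small expected move toward weaker inhibition in this assay (a 1.4-fold higher number from compound 3 to compound 4 (0.14 log units; within the scatter)) may not exceed the scatter. For compound 4 the estimated value is 1600 nM (range 350 nM to 8000 nM).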

Compound 4, half-maximal inhibitory concentration: 260 nM
Estimate against measurement, compound 4: 6.2-fold (0.79 log units) above; measured number outside the range, below it.
By their numbers in this assay, from the lowest: compound 4; then compounds 1 and 3 (each within the scatter of the next). At a limit, above all of these: compound 2.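

In this assay, methoxy in place of methylsulfanyl on an aromatic carbon gives a 4.5-fold lower number from compound 3 to compound 4 (0.65 log units; beyond the scatter), and the same swap also gives a 4.0-fold lower number from compound 1 to compound 4 (0.60 log units; beyond the scatter). Compounds 1 and 3 sat within the scatter of each other and could not show this, since both carry methylsulfanyl; only compound 4 reveals that methoxy here goes with stronger inhibition. Nothing measured on these compounds explains why the number falls. On these data alone, whether an ethoxy group, a hydroxyl or an amine on this aromatic carbon would keep or extend the gain stays open.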